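Dimethylamino to Diethylamino Across Two Cytotoxicity Cores

The source may report more compounds than this note shows. Statements on the series, on what has been measured and on what is new or still open speak of the compounds shown alone.

Compound 1 `CN(C)CCn1c(N)c(-c2nc3cc(Cl)ccc3[nH]2)c2nc(C#N)c(C#N)nc21` gives > 50000 nM in an ADME assay on HEK293 cells (Homo sapiens) for cytotoxicity, read by MTT assay, with a stated time of 48 h (on this read-out higher numbers stand for weaker inhibition and lower numbers for stronger inhibition), a limit of the assay.
Compound 2 `CCN(CC)CCn1c(N)c(-c2nc3cc(Cl)ccc3[nH]2)c2nc(C#N)c(C#N)nc21` gives > 50000 nM in this assay, also a limit.
Among the measured compounds shown here, compound 3 `CN(C)CCCCn1c(-c2c(N)n(C)c3nc(C#N)c(C#N)nc23)nc2ccccc21` gives 7130 nM in this assay, the only number among the three.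

Compound 1 and compound 2 share one core; compound 3 is built on a second core, and the difference between the two cores is not broken down here. From compound 1 to compound 2 the change is diethylamino in place of dimethylamino on a saturated chain carbon, two bonds along the chain from an aromatic nitrogen, and it made a step that the two limits leave unreadable from compound 1 to compound 2, since both compounds sit at the limit of > 50000 nM in this assay, at which 2 of the 3 values shown sit. Compound 4 `CCN(CC)CCCCn1c(-c2c(N)n(C)c3nc(C#N)c(C#N)nc23)nc2ccccc21` carries the same kind of change on the core of compound 3, (diethylamino in place of dimethylamino on a saturated chain carbon, four bonds along the chain from an aromatic nitrogen); the place differs only in being four bonds, not two, along the chain from an aromatic nitrogen. Because the step from compound 1 to compound 2 is a step that the two limits leave unreadable from compound 1 to compound 2, compound 4 is expected to move by about a 1.2-fold higher number from compound 3 to compound 4 (0.08 log units; within the scatter) from compound 3. Compound 4 is therefore estimated at 8500 nM, within 3000 nM to 25000 nM.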

Compound 4, half-maximal inhibitory concentration: 8820 nM
Compound 4: the middle estimate sits 1.0-fold (0.02 log units) below what was measured; the measured number falls inside the stated range.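

On the second core, diethylamino in place of dimethylamino gave a 1.2-fold higher number from compound 3 to compound 4 (0.09 log units; within the scatter) in this assay. This shows the size of the change on that one core only, and it does not show that the change behaves alike on both cores. Compound 1 and compound 2 both stand at a limit of the assay, so the matching step on their core cannot be read and the two cores cannot be compared for this change: the limit of > 50000 nM in this assay, at which 2 of the 4 values shown sit.

The compounds shown leave open how a piperidine or a morpholine in place of diethylamino would read on the core of compound 3. Also open, on these data alone, is how a 2-(diethylamino)ethyl chain would read on that core.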